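Cyclopropylmethyl ester step in a low-inhibition series

A few compounds are considered here, and "the series" means these few. Any claim that something is new, unique, unknown or untested is made for them only; others in the source may bear on it.

Measured compounds:
compound 1 `CC1=C(C(N)=O)C(c2ccsc2)NC(=O)N1`: 1%
compound 2 `CC1=C(C(=O)OC2CCCC2)C(c2ccsc2)NC(=O)N1`: 5%

In an assay on membranes from HeLa cells for displacement of a labelled ligand from adenosine receptor A3 (Homo sapiens), read by scintillation counting, with a stated time of 180 min, tested at 1 uM (on this read-out lower numbers stand for less inhibition and higher numbers for more inhibition at the one concentration tested (going by the name of the read-out)), compound 1 gives 1% and compound 2 gives 5%. Compound 2 holds the upper of the two numbers, but the step of a number 4 percentage points higher from compound 1 to compound 2 (within the scatter) does not separate the two compounds; both sit close to the floor of this assay.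

Compound 3 `CC1=C(C(=O)OCC2CC2)C(c2ccsc2)NC(=O)N1` is the next member. It differs from compound 2 in one place: cyclopropylmethyl in place of cyclopentyl on an oxygen next to a carbonyl group

Going by the values given here, the only measured step, a number 4 percentage points higher from compound 1 to compound 2 (within the scatter), concerns the same carbonyl position and replaced amino by cyclopentyloxy without moving the number beyond the scatter. Among the compounds with values here, no pair of measured compounds compares two different ester groups, so the present change is less well covered. Given that the one step at this position was flat, and that compound 2 itself reads low, no movement beyond the scatter is expected in this assay for compound 3: the step of no change at the digits printed from compound 2 to compound 3 (within the scatter) is estimated to be small. Compound 3 is expected to give about 5%, within -5% to 15%.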

Compound 3, a percentage reported as inhibition, at one concentration (the size of the read-out at that concentration, not a potency): 3%
For compound 3 the middle estimate is 2 percentage points above the measured one, within the range that was stated.
By their numbers in this assay, from the lowest: compounds 1, 3 and 2 (each within the scatter of the next).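

In this assay, going by these compounds alone, the first comparison of two ester groups at this carbonyl position is flat: cyclopropylmethyl in place of cyclopentyl on an oxygen next to a carbonyl group gives a number 2 percentage points lower from compound 2 to compound 3 (within the scatter) and so does not separate a five-membered ring from a three-membered ring in this ester. The comparison with the amino compound is also flat, with cyclopropylmethoxy in place of amino on a carbonyl carbon giving a number 2 percentage points higher from compound 1 to compound 3 (within the scatter), so two different ester groups now fail to stand apart from compound 1 in this assay. Nothing available explains why these three compounds stay together, and no supporting evidence bears on this result.

All three compounds remain near the floor of the read-out at the one concentration tested, so these numbers give no potency and no ranking among the groups compared. On these data alone, whether a benzyl ester, a longer straight-chain ester or a carboxylic acid at this carbonyl carbon would move the number beyond the usual scatter remains open.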